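Cutting back the side chain of compound 2

The compounds below may be only part of what the source reports. "The series", "measured", "known", "first", "only" and "open" are said of these compounds alone.

Of the compounds shown here, two on one shared core have numbers so far: compound 1 (`COc1ccc(N(C)c2nc(C)nc3ccccc23)cc1C(=O)NCC[Se]C#N`) and compound 2 (`COc1ccc(N(C)c2nc(C)nc3ccccc23)cc1C(=O)OCCCC[Se]C#N`). In a functional assay on HCT-116 cells (Homo sapiens) for inhibition, read by MTT assay, with a stated time of 48 h (on this read-out higher numbers stand for weaker inhibition and lower numbers for stronger inhibition), compound 1 gives 313 nM and compound 2 gives 662 nM. Compound 2 thus stands at the higher of the two numbers, the weaker inhibition of the pair. Compound 3 (`COc1ccc(N(C)c2nc(C)nc3ccccc23)cc1C[Se]C#N`) has not yet been measured. Its difference from compound 2 is a group of 4 heavy atoms (2 carbon, 1 nitrogen, 1 selenium; no ring) in place of a group of 10 heavy atoms (6 carbon, 1 nitrogen, 2 oxygen, 1 selenium; no ring), on an aromatic carbon, with the new group ortho to a methoxy group.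

Among the compounds with values here, only one measured step bears on this change: a 2.1-fold higher number from compound 1 to compound 2 (0.33 log units; beyond the scatter). That step is modest, and it swaps one group on a carbonyl carbon for another, whereas compound 3 has no carbonyl in this group at all, so it is only a loose guide. Still, the smaller group of compound 1 goes with the lower number, 313 nM. A modest step towards stronger inhibition in this assay is therefore expected. The expected change is a 1.9-fold lower number from compound 2 to compound 3 (0.28 log units; within the scatter). For compound 3 the estimated value is 350 nM, with an expected range of 120 nM to 1000 nM.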

Compound 3, half-maximal inhibitory concentration: 113 nM
Compound 3: middle estimate off by 3.1-fold (0.49 log units), on the high side; measured number outside the range, below it.
By their numbers in this assay, from the lowest: compound 3; then compound 1; then compound 2.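

Taking out the whole side chain up to the carbonyl and leaving a group of 4 heavy atoms on the aromatic carbon gives a 5.9-fold lower number from compound 2 to compound 3 (0.77 log units; beyond the scatter) in this assay and also a 2.8-fold lower number from compound 1 to compound 3 (0.44 log units; beyond the scatter) against the amide-linked compound. So a carbonyl at this position, whether in the ester or in the amide, is not needed for a low number here, and compound 3 gives the strongest inhibition of the three, with both of its steps beyond the scatter. Across these three compounds the shorter the link between the aromatic carbon and the selenium, the lower the number, although no information on why this is so is available.

The compounds shown cannot separate the loss of the carbonyl from the shortening of the chain, which a plain all-carbon chain of two or four methylene units ending in the same selenium and nitrile would pull apart. They also leave open whether the selenium itself matters at this position, as a sulfur atom in its place would show, and how an amine or a carboxylic acid on this aromatic carbon would read.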